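A few compounds are considered here, and "the series" means these few. Any claim that something is new, unique, unknown or untested is made for them only; others in the source may bear on it.

Measured so far in a functional assay with Homo sapiens as the target; a higher number here means a weaker inhibitor, a lower number a stronger inhibitor:
- compound 1, `CC(C)[C@H](NC(=O)COc1cccc2ccccc12)C(=O)N[C@@H](CC(=O)O)C(=O)COc1cccc(C(F)(F)F)c1`, gives 16600 nM
- compound 2, `CC(C)[C@H](NC(=O)COc1cccc2ccccc12)C(=O)N[C@@H](CC(=O)O)C(=O)COc1cc(F)c(F)cc1F`, gives 16700 nM
- compound 3, `CC(C)[C@H](NC(=O)COc1cccc2ccccc12)C(=O)N[C@@H](CC(=O)O)C(=O)COc1c(Cl)cccc1Cl`, gives 15300 nM

Compound 1 stands second highest of these three numbers. Its nearest neighbour is compound 2: a 1.0-fold higher number from compound 1 to compound 2 (0.00 log units; within the scatter). Its furthest is compound 3: a 1.1-fold lower number from compound 1 to compound 3 (0.04 log units; within the scatter). The remaining pair is no different: a 1.1-fold lower number from compound 2 to compound 3 (0.04 log units; within the scatter). All three compounds share the same core and differ only in the aryl group on the oxygen on a saturated carbon, and exchanging that whole group, whichever way it was done, left this assay within its scatter.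

Compound 4, `CC(C)[C@H](NC(=O)COc1cccc2ccccc12)C(=O)N[C@@H](CC(=O)O)C(=O)COc1cccc(C(F)(F)F)c1F`, keeps the aryl group of compound 1 and alters it in one place:

fluoro in place of hydrogen on an aromatic carbon

Within the data shown here, no measured step adds a single fluoro to this ring, so there is no direct precedent. The closest guide is that swapping out the entire 3-(trifluoromethyl)phenyl group, as in the steps from compound 1 to compound 2 and to compound 3, produced nothing beyond the scatter. A smaller alteration of the same group is therefore expected to give no step beyond the scatter either: a 1.0-fold lower number from compound 1 to compound 4 (0.02 log units; within the scatter). For compound 4 the estimate in this assay is 16000 nM, with a range from 8000 nM to 33000 nM.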

Compound 4, half-maximal inhibitory concentration: 18200 nM
Beside the measured number, compound 4's estimate is 1.1-fold (0.06 log units) below it; low and high end bracket the measured number.
By their numbers in this assay, from the lowest: compounds 3, 1, 2 and 4 (each within the scatter of the next).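

The earlier compounds shown here exchanged the whole aryl group, whereas compound 4 makes the smallest kind of change on it, a single fluoro on an aromatic carbon ortho to the trifluoromethyl group. This small edit also makes no measurable difference in this assay, with a 1.1-fold higher number from compound 1 to compound 4 (0.04 log units; within the scatter), so this ring position accepts a fluoro in place of hydrogen without a shift that can be told from the scatter. The new 2-fluoro-3-(trifluoromethyl)phenyl group also stands level with the two other aryl groups, with a 1.2-fold higher number from compound 3 to compound 4 (0.08 log units; within the scatter) and a 1.1-fold higher number from compound 2 to compound 4 (0.04 log units; within the scatter), and no further measurement is available to explain this flat result.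

Going by these compounds, all four compounds carry only fluoro, chloro or trifluoromethyl on this ring, so it remains open whether an amine or a carboxylic acid there would move the number beyond the scatter. All four also share the same core, so these compounds cannot show whether a change elsewhere in the molecule would shift the number in this assay.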